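The compounds below may be only part of what the source reports. "The series", "measured", "known", "first", "only" and "open" are said of these compounds alone.

Within the data shown here, compound 2 `COc1ccc(-c2c(Nc3cccc(C(F)(F)F)c3)c3ccccc3oc2=O)cc1` carries the only number in a functional assay on HepG2 cells (Homo sapiens) for antiproliferative activity, read by MTT assay, with a stated time of 48 h; on this read-out lower numbers stand for stronger inhibition and higher numbers for weaker inhibition: compound 2 gives 66400 nM. Compound 1 `COc1ccc(-c2c(Nc3ccc(NC(C)=O)cc3)c3ccccc3oc2=O)cc1` returns only an assay limit in this assay, > 100000 nM. Among the measured compounds shown here, the single measured step, an at least 1.5-fold lower number from compound 1 to compound 2 (0.17 log units; that floor lies within the scatter), concerns the group on a nitrogen on an aromatic ring and says nothing about the fused ring. Compound 3 `COc1ccc(-c2c(Nc3cccc(C(F)(F)F)c3)c3ccc(O)cc3oc2=O)cc1` differs from compound 2 by hydroxy in place of hydrogen on an aromatic carbon. For the measured compounds named here, no measured step touches that carbon, so for compound 3 the expected step is a 1.1-fold lower number from compound 2 to compound 3 (0.04 log units; within the scatter), not beyond the scatter. Compound 3 is estimated at 60000 nM in this assay, within 20000 nM to 150000 nM.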

Compound 3, half-maximal inhibitory concentration: 53600 nM
Compound 3: middle estimate off by 1.1-fold (0.05 log units), on the high side; the range from low to high includes it.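

Hydroxy in place of hydrogen on this aromatic carbon is the only change shown at this position, and in this assay it gives a 1.2-fold lower number from compound 2 to compound 3 (0.09 log units; within the scatter). The position therefore accepts a hydroxy, but the change yields no readable gain or loss against compound 2. Little room remains on the higher-number side of this read-out, where compound 1 sits: the limit of > 100000 nM in this assay, at which 1 of the 3 values shown sits.

As far as these compounds go, whether an amine or a carboxylic acid on this carbon would move the number beyond the scatter stays open. Also open, from the compounds shown here alone, is whether hydroxy here would behave alike with the 4-acetamidophenyl group of compound 1 on the nitrogen.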